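This account rests on a few compounds, and the source may have more. Where it says the series, first, only, none or still open, it means among the compounds named here.

Among the compounds with values here, in an assay for inhibition of mitogen-activated protein kinase kinase kinase 14 (Homo sapiens), read by luminescence and ADP-Glo, with a stated time of 120 min, in the presence of a further agent that is not named here (on this read-out higher numbers stand for weaker inhibition and lower numbers for stronger inhibition), compound 2 `CN1CCCN(c2ccc(C#CC(C)(O)c3nccs3)cc2Nc2ncnc3[nH]ccc23)CC1` gives 60.1 nM, the highest number of the two measured so far, though its gap to compound 1 is within the scatter. Compound 1 `CCN1CCN(c2ccc(C#CC(C)(O)c3nccs3)cc2Nc2ncnc3[nH]ccc23)CC1` gives 34.5 nM, and the step of a 1.7-fold higher number from compound 1 to compound 2 (0.24 log units; within the scatter) stays within the scatter. Compound 3 `CC(O)(C#Cc1ccc(OC2CCOCC2)c(Nc2ncnc3[nH]ccc23)c1)c1nccs1` differs from compound 2 by (oxan-4-yl)oxy in place of 4-methyl-1,4-diazepan-1-yl on an aromatic carbon. Within the data shown here, the single measured step swaps one nitrogen-containing ring for another and bears on this change only loosely; no step on hand replaces such a ring with an (oxan-4-yl)oxy group. The expected step in this assay is therefore a 1.2-fold higher number from compound 2 to compound 3 (0.07 log units; within the scatter), with no clear direction beyond the scatter. Compound 3 is estimated at 70 nM, within 20 nM to 250 nM.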

Compound 3, half-maximal inhibitory concentration: 112 nM
Beside the measured number, compound 3's estimate is 1.6-fold (0.20 log units) below it; the range from low to high includes it.
By their numbers in this assay, from the lowest: compounds 1, 2 and 3 (each within the scatter of the next, the first and the last beyond it).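

In this assay this position, para to the 3-hydroxy-3-(1,3-thiazol-2-yl)but-1-yn-1-yl group, still gives a measurable number with a ring lacking nitrogen: the change to (oxan-4-yl)oxy gives a 1.9-fold higher number from compound 2 to compound 3 (0.27 log units; within the scatter) and a 3.2-fold higher number from compound 1 to compound 3 (0.51 log units; beyond the scatter). Only the second step shows a modest loss, so the size of the effect depends on which nitrogen ring serves as the reference. Nothing on hand explains either step. Open, from the compounds shown here alone, is how a morpholin-4-yl ring, which joins ring oxygen and ring nitrogen, or an open-chain dimethylamino group would read at this position.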